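This account rests on a few compounds, and the source may have more. Where it says the series, first, only, none or still open, it means among the compounds named here.

Of the compounds shown here, two sharing one core have numbers so far in a functional assay on HBL-100 cells (Homo sapiens) for antiproliferative activity, read by sulforhodamine B assay, with a stated time of 48 h; a lower number here means a stronger inhibitor of growth, a higher number a weaker inhibitor of growth. In it, compound 2 `COC(=O)C#CC(CC(C)C)O/C=C/C(=O)OC` gives 330 nM. Compound 1 `COC(=O)C#CC(O/C=C/C(=O)OC)C(C)c1ccccc1`, which carries a larger group on the same carbon, gives 490 nM. The gap between these two values lies within the usual scatter of repeated measurements, so compound 2 cannot be ranked apart from compound 1.

Compound 3 `COC(=O)C#CC(O/C=C/C(=O)OC)C(C)C` has not yet been measured in this assay. It has isopropyl in place of isobutyl on a saturated chain carbon bound to an oxygen on an unsaturated carbon and a triple-bonded carbon. Going by the values given here, no measured pair shows this exact swap, so the expectation is indirect. Compound 1, at 490 nM, stays within the scatter of compound 2 despite its larger group, and the swap here is smaller. No step beyond the scatter is therefore expected in this assay, in either direction.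

The estimated step is a 1.2-fold higher number from compound 2 to compound 3 (0.08 log units; within the scatter). For compound 3 the expected value is 400 nM, with an estimated range of 180 nM to 900 nM.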

Compound 3, concentration for 50% growth inhibition: 450 nM
The estimate for compound 3 lay 1.1-fold (0.05 log units) below the measured number; the measured number falls inside the stated range.
By their numbers in this assay, from the lowest: compounds 2, 3 and 1 (each within the scatter of the next).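

In this assay the direct swap of isopropyl for isobutyl gives a 1.4-fold higher number from compound 2 to compound 3 (0.13 log units; within the scatter) and the swap of methyl for phenyl on the branch gives a 1.1-fold lower number from compound 1 to compound 3 (0.04 log units; within the scatter) in the same assay. Neither step separates its pair, so this position now has two single-change comparisons, and on this evidence neither trimming the isobutyl chain to isopropyl nor exchanging a phenyl ring for a methyl group on the branch gives a readable change in growth inhibition. Nothing available explains why these groups read alike.

On these data alone, all three compounds carry only carbon groups at this position, so it remains open whether an amine, a carboxylic acid or a much longer chain there would shift the number beyond the scatter. The shared core is also unchanged throughout, which leaves open what would follow from altering its two methyl esters or its triple bond, for instance by putting a carboxylic acid in place of an ester.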